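Cytotoxicity of Three Analogues and a Fourth to Come

The source may hold more compounds than are shown below. What is called first, only, known or untested is meant among the compounds shown, and "the series" means these compounds.

Compound 1 `CCC(CC)c1ccc2c(NCCCNCc3cccc(OC)c3O)ccnc2c1`: 410 nM
Compound 2 `COc1cccc(CNCCCNc2ccnc3cc(Oc4cccc(N(C)C)c4)ccc23)c1O`: 7300 nM
Compound 3 `COc1ccc(F)cc1CNCCCNc1ccnc2cc(-c3cccc4ccccc34)ccc12`: 16000 nM

Of the compounds shown here, three have been measured in an ADME assay on HepG2 cells (Homo sapiens) for cytotoxicity, read by luminescence, CellTiter-Glo and ATP content, with a stated time of 72 h; on this read-out higher numbers stand for an effect only at larger amounts of compound and lower numbers for an effect already at smaller amounts. Compound 3 stands highest of the three numbers; its nearest neighbour is compound 2, and compound 1 lies furthest below it. Among the measured compounds shown here, the one step measured between compounds that differ in a single place is an 18-fold higher number from compound 1 to compound 2 (1.25 log units; beyond the scatter), and it concerns the substituent on the shared core, not the benzyl group. Compound 4 `COc1cccc(CNCCCNc2ccnc3cc(-c4cccc5ccccc45)ccc23)c1O` has not yet been measured. It differs from compound 3 by 2-hydroxy-3-methoxyphenyl in place of 5-fluoro-2-methoxyphenyl on a saturated chain carbon bound to an amine nitrogen. For the measured compounds named here, no measured step touches that position: compounds 2 and 3 differ in two places at once, so their values show only that compound 3 gives the higher number. Compounds 1 and 2 both carry 2-hydroxy-3-methoxyphenyl, which is the group that enters. Going by the values given here, with no step bearing directly on the change, compound 4 is expected to stay close to compound 3 in this assay, a step of a 1.1-fold lower number from compound 3 to compound 4 (0.06 log units; within the scatter) at most within the scatter. Compound 4 is estimated at 14000 nM, between 6000 nM and 35000 nM.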

Compound 4, half-maximal effective concentration: 2520 nM
The estimate for compound 4 lay 5.6-fold (0.74 log units) above the measured number; measured number below the stated range.
By their numbers in this assay, from the lowest: compound 1; then compound 4; then compound 2; then compound 3.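

Swapping 5-fluoro-2-methoxyphenyl for 2-hydroxy-3-methoxyphenyl on a saturated chain carbon bound to an amine nitrogen gives the first direct reading at this position, and in this assay the change is not silent: it gives a 6.3-fold lower number from compound 3 to compound 4 (0.80 log units; beyond the scatter). With 2-hydroxy-3-methoxyphenyl held constant, the group on the aromatic carbon can also be compared further, since naphthalen-1-yl in place of 3-(dimethylamino)phenoxy gives a 2.9-fold lower number from compound 2 to compound 4 (0.46 log units; beyond the scatter) and naphthalen-1-yl in place of pentan-3-yl gives a 6.1-fold higher number from compound 1 to compound 4 (0.79 log units; beyond the scatter). Nothing available here accounts for any of these steps.

The step changes several features together, so the compounds shown leave open how much of it belongs to the fluorine, the hydroxyl or the methoxy placement, which a 2-hydroxyphenyl or 3-methoxyphenyl group could help separate. Going by these compounds, it is also read only with naphthalen-1-yl on the shared core, so its size with pentan-3-yl or 3-(dimethylamino)phenoxy there remains open.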